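Swapping a Naphthyl Group for a Tert-Butylphenyl

The source may hold more compounds than are shown below. What is called first, only, known or untested is meant among the compounds shown, and "the series" means these compounds.

In a functional assay on MCF7 cells (Homo sapiens) for antiproliferative activity, read by MTT assay, with a stated time of 72 h, tested at 100 uM (on this read-out lower numbers stand for a stronger effect and higher numbers for a weaker effect at the one concentration tested), compound 2 `COC(C(=O)OC(C)Cn1cnc2c1c(=O)n(C)c(=O)n2C)c1ccc2ccccc2c1` gives 83.7%, the highest number of the three shown. Compound 1 `COC(C(=O)OC(C)Cn1cnc2c1c(=O)n(C)c(=O)n2C)c1cccc2ccccc12` gives 83.3%; the step of a number 0.4 percentage points higher from compound 1 to compound 2 (within the scatter). Compound 3 `CC(Cn1cnc2c1c(=O)n(C)c(=O)n2C)OCc1cn(CCCn2cnc3c(Br)c(Br)c(Br)c(Br)c32)nn1`, built on a different skeleton, gives 2%, far lower. Compound 4 `COC(C(=O)OC(C)Cn1cnc2c1c(=O)n(C)c(=O)n2C)c1ccc(C(C)(C)C)cc1` differs from compound 2 by 4-(tert-butyl)phenyl in place of naphthalen-2-yl on a saturated chain carbon bound to a carbonyl carbon and an oxygen on a saturated carbon. Within the data shown here, only one measured step touches this position: the move of the naphthyl attachment point from compound 1 to compound 2 stayed within the scatter. Among the measured compounds shown here, no measured step shows a naphthyl group giving way to a phenyl ring, so the expected step of a number 0.3 percentage points higher from compound 2 to compound 4 (within the scatter) is small, with no direction favoured beyond the scatter. Compound 4 is therefore estimated at 84%, between 68% and 98%.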

Compound 4, a percentage reported as activity, at one concentration (the size of the read-out at that concentration, not a potency): 63.5%
Compound 4: middle estimate off by 20.5 percentage points, on the high side; the measured number lies below the stated range.
By their numbers in this assay, from the lowest: compound 3; then compound 4; then compounds 1 and 2 (each within the scatter of the next).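

The position does respond to its group, even though moving the naphthyl attachment point did not register. In this assay, the 4-(tert-butyl)phenyl group gives a stronger effect than either naphthyl group (a number 20.2 percentage points lower from compound 2 to compound 4 (beyond the scatter)) and (a number 19.8 percentage points lower from compound 1 to compound 4 (beyond the scatter)). This happens with the same number of heavy atoms, but with one aromatic ring instead of two. Nothing available here explains the change. Whether the gain comes from losing the second ring or from the tert-butyl group itself stays open, and a phenyl ring carrying an amine or a carboxylic acid in place of tert-butyl also remains untested among the compounds shown.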